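Working notes: from compound 2 to compound 4

The compounds below may be only part of what the source reports. "The series", "measured", "known", "first", "only" and "open" are said of these compounds alone.

Measured so far in a functional assay on MCF7 cells (Homo sapiens) for antiproliferative activity, read by MTT assay, with a stated time of 24 h (a lower number here means a stronger inhibitor, a higher number a weaker inhibitor), on the series:
- compound 1 `CCCCc1oc2ccccc2c1C(=O)c1ccc(OCC(=O)N2CCCCC2)cc1` gives > 50000 nM as a limit of the assay, not a number
- compound 2 `CCCCc1oc2ccccc2c1C(=O)c1ccc(OCC(=O)N2CCOCC2)cc1` gives 34000 nM as a number
- compound 3 `CCCCc1oc2ccccc2c1C(=O)c1ccc(OCC(=O)N2CCN(C(=O)OC(C)(C)C)CC2)cc1` gives 42200 nM as a number

Among the measured compounds shown here, compound 2 and compound 3 hold the only two numbers in the set, and they lie within the scatter of each other. The remaining entry, for compound 1, is a limit. Compound 4 `CCCCc1oc2ccccc2c1C(=O)c1ccc(OCC(=O)N[C@H](C)c2ccccc2)cc1` is still to be measured. Taken from compound 2, the change is (1-phenylethyl)amino in place of morpholin-4-yl on a carbonyl carbon and in words it puts (1-phenylethyl)amino in place of morpholin-4-yl on a carbonyl carbon.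

For the measured compounds named here, only one measured step bears on that carbonyl carbon: an at least 1.4-fold lower number from compound 1 to compound 2 (0.16 log units; that floor lies within the scatter) and it starts from a limit, so it sets no size for a larger change. Going by the values given here, no measured compound carries (1-phenylethyl)amino, so the direction stays open. The set also shows the limit of > 50000 nM in this assay, at which 1 of the 3 values shown sits, and a limit is therefore a real possibility for compound 4.

In this assay no step beyond the scatter is expected. The estimated step is a 1.1-fold lower number from compound 2 to compound 4 (0.05 log units; within the scatter) and it is not expected to pass the scatter. For compound 4 the estimate is 30000 nM with 12000 nM to 50000 nM as the expected range.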

Compound 4, half-maximal inhibitory concentration: 14100 nM
For compound 4 the middle estimate is 2.1-fold (0.33 log units) above the measured one; measured number inside the range.
By their numbers in this assay, from the lowest: compound 4; then compounds 2 and 3 (each within the scatter of the next). At a limit, above all of these: compound 1.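

In this assay, among the compounds shown here, (1-phenylethyl)amino in place of morpholin-4-yl on a carbonyl carbon gives a 2.4-fold lower number from compound 2 to compound 4 (0.38 log units; beyond the scatter) and is the first step between two numbers to pass the scatter. So this position can move the read-out, which the earlier compounds could not show, since their only step started from a limit and its floor lay within the scatter. Against piperidin-1-yl, the same group gives an at least 3.5-fold lower number from compound 1 to compound 4 (0.54 log units; beyond the scatter) as a floor only, and the limit belongs to compound 1, so that step has no upper size: the limit of > 50000 nM in this assay, at which 1 of the 4 values shown sits.

The step to compound 4 brings in a six-membered aromatic ring of carbon only, a hydrogen-bond donor and a defined stereocentre together, and the compounds shown do not separate these three changes. A benzylamino group, a methylamino group or the opposite enantiomer of (1-phenylethyl)amino on the same carbonyl carbon would each bear on one of them, and so show which part of the change goes with the lower number.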